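The source may report more compounds than this note shows. Statements on the series, on what has been measured and on what is new or still open speak of the compounds shown alone.

Compound 3 `Cc1ccc(NC(=O)c2cccc(C(F)(F)F)c2)cc1N1Cc2cnc(O[C@H]3CCNC3)nc2N(C)C1=O` stands at the edge of what the numbers here resolve: in an ADME assay on BaF3 cells (Mus musculus) for antiproliferative activity, read by CellTiter-Glo and CCK-8 assay, with a stated time of 72 h (on this read-out lower numbers stand for stronger inhibition of growth and higher numbers for weaker inhibition of growth), compound 3 gives only a limit, > 10000 nM, and not a number. Two measured compounds lead to it. Compound 1 `Cc1ccc(Nc2ncc3c(n2)N(C)C(=O)N(c2cc(NC(=O)c4cccc(C(F)(F)F)c4)ccc2C)C3)cc1` gives 8000 nM in this assay, and compound 2 `Cc1ccc(NC(=O)c2cccc(C(F)(F)F)c2)cc1N1Cc2cnc(O[C@H]3CCN(C(=O)OC(C)(C)C)C3)nc2N(C)C1=O` gives 8380 nM in this assay. The step of an at least 1.2-fold higher number from compound 1 to compound 3 (0.09 log units; that floor lies within the scatter) and the step of an at least 1.1-fold higher number from compound 2 to compound 3 (0.07 log units; that floor lies within the scatter) are each known only as a floor, and both floors lie within the scatter, so compound 3 is not set apart from compound 1 or compound 2 by these data; all three sit at or near (the limit of > 10000 nM in this assay, at which 1 of the 3 values shown sits). Compound 4 `Cc1ccc(Oc2ncc3c(n2)N(C)C(=O)N(c2cc(NC(=O)c4cccc(C(F)(F)F)c4)ccc2C)C3)cc1N` is reached from compound 3 by 3-amino-4-methylphenyl in place of pyrrolidin-3-yl on an oxygen on an aromatic ring. Going by the values given here, only the step from compound 1 to compound 3 touches the same position, exchanging (4-methylphenyl)amino for (pyrrolidin-3-yl)oxy, and it stayed within the scatter; the step from compound 2 to compound 3 concerns the tert-butoxycarbonyl elsewhere. Because compound 1 gives 8000 nM with an aromatic ring at this position, compound 4 is expected to land in the same region. The expected step is an at least 1.1-fold lower number from compound 3 to compound 4 (0.04 log units; that floor lies within the scatter), within the scatter. Compound 4 in this assay is estimated at 9000 nM, from 4000 nM to 20000 nM.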

Compound 4, concentration for 50% growth inhibition: > 10000 nM
Compound 4 was reported as a limit; the forecaster's own chance of this, stated with the estimate: 40%; middle value at least 1.1-fold (0.04 log units) from the limit.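

In this assay, compound 4 gives > 10000 nM, which is a limit of the assay and not a number. The results show an at least 1.2-fold higher number from compound 1 to compound 4 (0.09 log units; that floor lies within the scatter) and an at least 1.1-fold higher number from compound 2 to compound 4 (0.07 log units; that floor lies within the scatter), so these data do not set compound 4 apart from either compound, and the step between the limits of compound 3 and compound 4 cannot be read. What is new is that the 3-amino-4-methylphenyl group on this oxygen, an aromatic ring in place of the pyrrolidin-3-yl ring, also fails to give a readable number, so this exchange at this position brings the series no clear gain and leaves its values crowded at the top of the range: the limit of > 10000 nM in this assay, at which 2 of the 4 values shown sit.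

The compounds shown leave open whether a plain phenoxy group, or a 3-amino-4-methylphenylamino group joined through nitrogen instead of oxygen, would separate the effect of the amine on the ring from that of the linking atom. They also leave open whether a smaller group at this position, such as methoxy or dimethylamino, would give a value clearly beneath the limit.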